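Aryl swaps and oral exposure in the oxalamide-linked piperazine series

The source may report more compounds than this note shows. Statements on the series, on what has been measured and on what is new or still open speak of the compounds shown alone.

Measured so far in an ADME assay on the whole organism (Rattus norvegicus, strain Sprague-Dawley) for pharmacokinetics, using cassette dosing, at a dose of 1 mg/kg by the oral route; a lower number here means that a smaller share of the oral dose reaches the circulation, a higher number that a larger share of the oral dose reaches the circulation:
- compound 1 `O=C(Nc1ccc2[nH]c(=O)oc2c1)C(=O)N1CCN(c2ccc(C(F)(F)F)cc2)CC1`: 24.8%
- compound 2 `O=C(Nc1ccc2[nH]c(=O)oc2c1)C(=O)N1CCN(c2ccc(F)c(Cl)c2)CC1`: 24.6%
- compound 3 `O=C(Nc1ccc2[nH]c(=O)oc2c1)C(=O)N1CCN(c2ccc(Cl)c(F)c2)CC1`: 28.2%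

Compound 3 cannot be separated from the other two on these numbers. The measured steps are a number 3.4 percentage points higher from compound 1 to compound 3 (within the scatter) and a number 3.6 percentage points higher from compound 2 to compound 3 (within the scatter), and both lie within the scatter. The remaining step, a number 0.2 percentage points lower from compound 1 to compound 2 (within the scatter), also lies within the scatter.

Next is compound 4 `COc1ccc(N2CCN(C(=O)C(=O)Nc3ccc4[nH]c(=O)oc4c3)CC2)cc1F`, which takes 4-chloro-3-fluorophenyl to 3-fluoro-4-methoxyphenyl: methoxy in place of chloro on an aromatic carbon. The methoxy stands in place of chloro on an aromatic carbon, ortho to a fluoro group and para to a large group.

Going by the values given here, no measured step exchanges chloro for methoxy, so there is no direct precedent. The nearest evidence is the three changes of the same aryl group, and none of them moved this assay beyond the scatter. The largest of them is a number 3.6 percentage points higher from compound 2 to compound 3 (within the scatter). The same is therefore expected here, with no step beyond the scatter and no firm direction, although a new group on this carbon leaves the outcome less certain than the three measured steps alone suggest.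

The expected change is a number 3.2 percentage points lower from compound 3 to compound 4 (within the scatter). For compound 4 the estimate is 25%, with an expected range of 13% to 38%.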

Compound 4, oral bioavailability: 0.6%
Estimate against measurement, compound 4: 24.4 percentage points above; measured number outside the range, below it.
By their numbers in this assay, from the lowest: compound 4; then compounds 2, 1 and 3 (each within the scatter of the next).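

In this assay the aryl group on the amine nitrogen in a ring proves far from indifferent: the earlier exchanges among aryl groups all stayed within the scatter, whereas methoxy in place of chloro, on an aromatic carbon ortho to a fluoro group and para to a large group, gives a number 27.6 percentage points lower from compound 3 to compound 4 (beyond the scatter) here. The result does not depend on compound 3 as the reference, since the 3-fluoro-4-methoxyphenyl group also gives a number 24 percentage points lower from compound 2 to compound 4 (beyond the scatter) and a number 24.2 percentage points lower from compound 1 to compound 4 (beyond the scatter), leaving compound 4 alone on one side and the three earlier compounds together on the other. Nothing available on these compounds bears on the reason for this step.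

The compounds shown leave open whether the loss belongs to methoxy alone or extends to other groups on this carbon, such as a hydroxy, an ethoxy, a methyl or a dimethylamino group. They also leave open whether methoxy on this carbon has the same outcome when a hydrogen stands in place of the fluoro group.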